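Working notes on a cyclic-diamine series: fluoro to methoxy step

This account rests on a few compounds, and the source may have more. Where it says the series, first, only, none or still open, it means among the compounds named here.

Measured in an assay on mitochondria from L6 cells (Rattus norvegicus) for activation, with a stated time of 90 min; a higher number here means that more compound is needed for the effect, a lower number that less compound is needed:
Compound 1 `C1CCC(Nc2nc3nonc3nc2NC2CCCC2)C1` gives 45000 nM
Compound 2 `Cc1cccc(Nc2nc3nonc3nc2Nc2cccc(C)c2)c1` gives 2100 nM
Compound 3 `Fc1cccc(Nc2nc3nonc3nc2Nc2ccccc2F)c1` gives 190 nM

Compound 3 carries the lowest number of the three. Compound 2 sits above it, beyond the scatter, and compound 1 sits furthest from it, also beyond the scatter. Both aryl-bearing compounds lie well under compound 1, though with only one non-aryl entry no pattern is claimed.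

Compound 4 `COc1cccc(Nc2nc3nonc3nc2Nc2ccccc2F)c1` is not yet measured and differs from compound 3 in one place: methoxy in place of fluoro on an aromatic carbon. Among the measured compounds shown here, no measured pair shows this change, so its size is not anchored by data. A modest rise in this assay is expected, a 2.1-fold higher number from compound 3 to compound 4 (0.32 log units; beyond the scatter), though a result inside the scatter would not surprise. For compound 4 the estimated value is 400 nM, with a range from 130 nM to 1300 nM.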

Compound 4, half-maximal effective concentration: 830 nM
The estimate for compound 4 lay 2.1-fold (0.32 log units) below the measured number, within the range that was stated.
By their numbers in this assay, from the lowest: compound 3; then compound 4; then compound 2; then compound 1.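

In this assay, among the compounds shown here, the change from 3-fluorophenyl to 3-methoxyphenyl gives a 4.4-fold higher number from compound 3 to compound 4 (0.64 log units; beyond the scatter) and this is the first one-place comparison. The number therefore responds to the group carried at this position on the aromatic ring, and one measured pair now anchors the size of this change. Nothing at hand bears on the reason for the rise.

Still open, on these data alone, is whether a hydroxy group, an amine or a carboxylic acid at this place would raise or lower the number. Also open, as far as these compounds go, is whether methoxy in place of fluoro on the second aryl ring gives a step of similar size.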